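The source may report more compounds than this note shows. Statements on the series, on what has been measured and on what is new or still open speak of the compounds shown alone.

In a functional assay on SK-BR-3 cells (Homo sapiens) for cytotoxicity, read by MTT assay, with a stated time of 72 h (a higher number here means a weaker inhibitor, a lower number a stronger inhibitor), compound 1 `N[C@H]1CC[C@H](Nc2c(C(=O)NCc3ccco3)nc(Br)c3cccnc23)CC1` gives 10000 nM and compound 2 `COc1ccc(CNC(=O)c2nc(Br)c3cccnc3c2N[C@H]2CC[C@H](N)CC2)cc1` gives 5000 nM. Within the data shown here, these two values lie within the usual scatter of each other, so compound 2 cannot be separated from the only other compound measured so far. Compound 3 `N[C@H]1CC[C@H](Nc2c(C(=O)NCc3ccc(Cl)cc3Cl)nc(Br)c3cccnc23)CC1` keeps the shared core and differs from compound 2 in one group: 2,4-dichlorophenyl in place of 4-methoxyphenyl on a saturated chain carbon bound to an amide-type nitrogen. Put simply, 2,4-dichlorophenyl stands in place of 4-methoxyphenyl on a saturated chain carbon bound to an amide-type nitrogen. Among the measured compounds shown here, one measured step bears on this place, a 2.0-fold lower number from compound 1 to compound 2 (0.30 log units; within the scatter), with 4-methoxyphenyl in place of furan-2-yl, and it stays within the scatter. For the measured compounds named here, no measurement yet covers the entering group, so no change beyond the scatter is expected in this assay. The expected change is a 1.3-fold lower number from compound 2 to compound 3 (0.10 log units; within the scatter). Compound 3 is therefore expected at 4000 nM, with an estimated range from 1500 nM to 10000 nM.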

Compound 3, half-maximal inhibitory concentration: 6000 nM
Compound 3: the middle estimate sits 1.5-fold (0.18 log units) below what was measured, within the range that was stated.
By their numbers in this assay, from the lowest: compounds 2, 3 and 1 (each within the scatter of the next).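

In this assay, exchanging 4-methoxyphenyl for 2,4-dichlorophenyl gives a 1.2-fold higher number from compound 2 to compound 3 (0.08 log units; within the scatter), and exchanging furan-2-yl for 2,4-dichlorophenyl gives a 1.7-fold lower number from compound 1 to compound 3 (0.22 log units; within the scatter). Both steps stay within the scatter, so the three aromatic rings tried on a saturated chain carbon bound to an amide-type nitrogen cannot be told apart in this assay. This also holds for the first chlorine-bearing ring at this place, even though the exchange swaps a group with one hydrogen-bond acceptor for one with none. Nothing available here explains why these groups read alike.

On these data alone, it remains open whether a group of another kind at this place, such as a carboxylic acid, an amine or a longer saturated chain, would move the number beyond the scatter. With all three compounds this close together, the shown data give no order among the groups.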